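Series notes: ester and chain variations in a dienoate set

A few compounds are considered here, and "the series" means these few. Any claim that something is new, unique, unknown or untested is made for them only; others in the source may bear on it.

Compound 1 `CCOC(=O)/C=C(C)/C=C/CC(C)CCCC(C)(C)OC` is the smallest ester of the three measured; in a physicochemical assay for lipophilicity (on this read-out lower numbers stand for lower lipophilicity and higher numbers for higher lipophilicity), compound 1 gives 5.54, the lowest of the three numbers. Compound 2 `C=CC(C)OC(=O)/C=C(C)/C=C/CC(C)CCCC(C)(C)OC` gives 5.94, and compound 3 `COC(C)(C)CCCC(C)C/C=C/C(C)=C/C(=O)OC1CCC1` gives 6.44. The measured steps all lie on the ester side: a number 0.40 log units higher from compound 1 to compound 2 (beyond the scatter), a number 0.90 log units higher from compound 1 to compound 3 (beyond the scatter) and a number 0.50 log units higher from compound 2 to compound 3 (beyond the scatter), and in each the ester group that grew in heavy atoms gave the higher number.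

Compound 4 `CCOC(=O)/C=C(C)/C=C/CC(C)CCC(=O)C(C)C` changes the other end of the chain: isopropylcarbonyl in place of 2-methoxy-2-methylpropyl on a saturated chain carbon, four bonds along the chain from a double-bonded chain carbon. Going by the values given here, no measured step touches this part of the molecule, so the ester-side steps bear on it only by the rough reading that a group with fewer heavy atoms has so far gone with a lower number; here the entering group carries one heavy atom fewer than the leaving group. A modest fall beyond the scatter is therefore expected, a number 0.84 log units lower from compound 1 to compound 4 (beyond the scatter). Compound 4 is estimated at 4.7, within 4.2 to 5.2.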

Compound 4, partition coefficient: 4.3
For compound 4 the middle estimate is 0.40 log units above the measured one; the range from low to high includes it.
By their numbers in this assay, from the lowest: compound 4; then compound 1; then compound 2; then compound 3.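

The far end of the chain moves this assay more than any ester change so far: isopropylcarbonyl in place of 2-methoxy-2-methylpropyl gives a number 1.24 log units lower from compound 1 to compound 4 (beyond the scatter), a large step where the ester-side steps are modest. The two groups match in hydrogen-bond donors, hydrogen-bond acceptors and net charge, so those counts do not separate them, and the heavy-atom reading taken from the ester side gives the direction here but not the size. Nothing at hand accounts for the size of this step.

Isopropylcarbonyl and 2-methoxy-2-methylpropyl differ in more than one feature, so a simple alcohol or a plain alkyl chain at this place would be needed to show which feature goes with the step. Going by these compounds alone, whether the ester-side steps carry over to this chain end also remains open, as compound 4 is its only example here.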